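The compounds below may be only part of what the source reports. "The series", "measured", "known", "first", "only" and "open" are said of these compounds alone.

In a functional assay on NCI-H1581 cells (Homo sapiens) for antiproliferative activity, read by CCK-8 assay, with a stated time of 72 h (on this read-out higher numbers stand for weaker inhibition and lower numbers for stronger inhibition), compound 1 (`COc1cc(OC)c(Cl)c(-c2ccc3c(NC(=O)c4ccc(N5CCCN(C)CC5)cc4)n[nH]c3n2)c1Cl`) gives 1.3 nM and compound 2 (`CCN1CCN(c2ccc(C(=O)Nc3n[nH]c4nc(-c5c(Cl)c(OC)cc(OC)c5Cl)ccc34)cc2)CC1`) gives 0.7 nM while compound 3 (`COc1cc(OC)c(Cl)c(-c2ccc3c(NC(=O)c4ccc(N5CCN(C)CC5)s4)n[nH]c3n2)c1Cl`) gives 3.7 nM as the highest of the three numbers, beyond the scatter from both others. Compound 4 (`COc1cc(OC)c(Cl)c(-c2ccc3c(NC(=O)c4ccc(N5CCNCC5)cc4)n[nH]c3n2)c1Cl`) has not yet been measured. It differs from compound 3 on a carbonyl carbon (a group of 12 heavy atoms (10 carbon, 2 nitrogen; one six-membered non-aromatic ring with 2 hetero atoms, one six-membered aromatic ring of carbon only) in place of a group of 12 heavy atoms (9 carbon, 2 nitrogen, 1 sulfur; one five-membered aromatic ring with 1 hetero atom, one six-membered non-aromatic ring with 2 hetero atoms), on a carbonyl carbon): 4-(piperazin-1-yl)phenyl replaces the group with the five-membered aromatic ring, which gives compound 4 the six-membered aromatic ring of carbon only also found in compounds 1 and 2. For the measured compounds named here, no measured step makes this exchange. Going by the values given here, the only step available is a 1.9-fold lower number from compound 1 to compound 2 (0.27 log units; within the scatter) for 4-ethylpiperazin-1-yl in place of 4-methyl-1,4-diazepan-1-yl on an aromatic carbon, and it shows that this one change stayed within the scatter. The expectation therefore rests on compound 1 at 1.3 nM and compound 2 at 0.7 nM and points to a lower number than that of compound 3. Neither compound has the piperazine of compound 4 without a further group, so the range is kept wide. The estimated change is a 2.5-fold lower number from compound 3 to compound 4 (0.39 log units; beyond the scatter) in this assay and is only an expectation. For compound 4 the estimate is 1.5 nM (expected range 0.5 nM to 5 nM).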

Compound 4, half-maximal inhibitory concentration: 1.4 nM
Beside the measured number, compound 4's estimate is 1.1-fold (0.03 log units) above it, and the stated range covers the measured number.
By their numbers in this assay, from the lowest: compounds 2, 1 and 4 (each within the scatter of the next); then compound 3.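

In this assay, for the compounds shown here, replacing the group with the five-membered aromatic ring by 4-(piperazin-1-yl)phenyl on the carbonyl carbon gives a 2.6-fold lower number from compound 3 to compound 4 (0.42 log units; beyond the scatter), a modest change but the only new step beyond the scatter, and it ties the six-membered aromatic ring of carbon only to a lower number than the five-membered ring gives, though the methyl on the ring amine nitrogen of compound 3 is lost in the same exchange. At the far end of the group the picture is flat: hydrogen in place of ethyl on an amine nitrogen in a ring gives a 2.0-fold higher number from compound 2 to compound 4 (0.30 log units; within the scatter), and piperazin-1-yl in place of 4-methyl-1,4-diazepan-1-yl gives a 1.1-fold higher number from compound 1 to compound 4 (0.03 log units; within the scatter), both within the scatter, so neither the ethyl nor the larger ring is needed for this level of activity. Nothing available explains these results.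

The compounds shown leave open how the step from compound 3 divides between the aromatic ring and the methyl, since none of them joins 4-methylpiperazin-1-yl to the six-membered aromatic ring of carbon only. They also leave open whether a morpholine in place of the piperazine, or an acetyl group or a hydroxyethyl chain on its nitrogen, would stay in the same range.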